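The source may hold more compounds than are shown below. What is called first, only, known or untested is meant among the compounds shown, and "the series" means these compounds.

Compound 1 `c1ccc(-c2ccc3c(NCCCNCc4ccco4)ccnc3c2)cc1` gives 5920 nM in an ADME assay on HepG2 cells (Homo sapiens) for cytotoxicity, read by luminescence, CellTiter-Glo and ATP content, with a stated time of 72 h; a lower number here means that less compound is needed, a higher number that more compound is needed for the effect.
Compound 2 `COc1cccc(CNCCCNc2ccnc3cc(-c4ccccc4)ccc23)c1O` gives 3210 nM.
Compound 3 `COc1ccc(F)cc1CNCCCNc1ccnc2cc(-c3ccccc3)ccc12` gives 2960 nM.

Among these three numbers compound 2 stands second highest. Its nearest neighbour is compound 3, reached by a 1.1-fold lower number from compound 2 to compound 3 (0.04 log units; within the scatter); its furthest is compound 1, from which a 1.8-fold lower number from compound 1 to compound 2 (0.27 log units; within the scatter) leads to compound 2. Both steps lie within the scatter, as does a 2.0-fold lower number from compound 1 to compound 3 (0.30 log units; within the scatter), so the three measured compounds cannot be told apart in this assay.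

Compound 4 `COc1cccc(CNCCCNc2ccnc3cc(Cc4cccc(C(F)(F)F)c4)ccc23)c1O` differs from compound 2 at the other end of the molecule: 3-(trifluoromethyl)benzyl in place of phenyl on an aromatic carbon. Every measured step concerns the group on a saturated chain carbon bound to an amine nitrogen, not the aromatic carbon of the shared core, so none of them bears directly on this change. Within the data shown here, the data give no step at this position at all, and the steps that exist were all small. The expectation is therefore no step beyond the scatter in this assay, with the range widened for the lack of a comparable example.

Compound 4 is estimated at 3200 nM, between 1100 nM and 9000 nM. This estimate means an expected step of a 1.0-fold lower number from compound 2 to compound 4 (0.00 log units; within the scatter).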

Compound 4, half-maximal effective concentration: 1720 nM
The estimate for compound 4 lay 1.9-fold (0.27 log units) above the measured number; low and high end bracket the measured number.
By their numbers in this assay, from the lowest: compounds 4, 3, 2 and 1 (each within the scatter of the next, the first and the last beyond it).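

Among these compounds, this is the first step seen at the aromatic carbon of the shared core, where the earlier compounds changed only the group on the saturated chain. Replacing phenyl with 3-(trifluoromethyl)benzyl adds heavy atoms, including fluorine, yet gives a 1.9-fold lower number from compound 2 to compound 4 (0.27 log units; within the scatter) in this assay, so even this larger group leaves compound 4 indistinguishable from compound 2 in this read-out. No measurement offers an explanation for this result.

Going by these compounds, compound 4 brings in the extra carbon and the trifluoromethyl group together, so their separate contributions remain unknown, and a plain benzyl group would be needed to tell them apart. On these data alone, it also remains open whether a group of another kind at this aromatic carbon, such as an amine or a carboxylic acid, would produce a step beyond the scatter.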